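The compounds below may be only part of what the source reports. "The series", "measured", "known", "first", "only" and "open" are said of these compounds alone.

Measured so far in a functional assay for inhibition, with Homo sapiens as the target; on this read-out higher numbers stand for weaker binding and lower numbers for tighter binding:
- compound 1 `O=C(O)CC/C=C\CC1COC(c2ccc([N+](=O)[O-])cc2)OC1c1cccnc1` gives 933 nM
- compound 2 `O=C(O)CC/C=C\CC1COC(c2ccc(Cl)cc2Cl)OC1c1cccnc1` gives 891 nM
- compound 3 `CSc1ccc(OC(C)(C)C2OCC(C/C=C\CCC(=O)O)C(c3cccnc3)O2)c([N+](=O)[O-])c1` gives 4.47 nM

Compound 3 has the lowest number of the three, and its gap to each of the other two lies beyond the scatter.

The next structure is compound 4 `COc1ccc(OC(C)(C)C2OCC(C/C=C\CCC(=O)O)C(c3cccnc3)O2)cc1`, which carries 4-methoxyphenyl on an oxygen on a saturated carbon: a group of 8 heavy atoms (7 carbon, 1 oxygen; one six-membered aromatic ring of carbon only) in place of a group of 11 heavy atoms (7 carbon, 1 nitrogen, 2 oxygen, 1 sulfur; one six-membered aromatic ring of carbon only), on an oxygen on a saturated carbon. Going by the values given here, only one measured step is available, a 1.0-fold lower number from compound 1 to compound 2 (0.02 log units; within the scatter). It lies within the scatter, but it concerns a saturated ring carbon rather than this oxygen, so it bears only weakly on the change. Among the compounds with values here, no measured pair isolates the group that leaves. Compound 3 at 4.47 nM sits at the low end of the series, so a move toward a higher number seems more likely than a further drop, though its size is poorly constrained.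

The expected change is a 4.5-fold higher number from compound 3 to compound 4 (0.65 log units; beyond the scatter), beyond the scatter. The estimate for compound 4 is 20 nM, with an expected range from 5 nM to 90 nM.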

Compound 4, dissociation constant: 302 nM
Compound 4: middle estimate off by 15-fold (1.18 log units), on the low side; the whole stated range lies below it.
By their numbers in this assay, from the lowest: compound 3; then compound 4; then compounds 2 and 1 (each within the scatter of the next).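

In this assay, going by these compounds alone, the group on an oxygen on a saturated carbon matters strongly: 4-methoxyphenyl in place of the group of 11 heavy atoms gives a 68-fold higher number from compound 3 to compound 4 (1.83 log units; beyond the scatter), whereas the only earlier step, a 1.0-fold lower number from compound 1 to compound 2 (0.02 log units; within the scatter), concerned a saturated ring carbon and lay within the scatter. Both groups hold one six-membered aromatic ring of carbon only and carry no net charge, so a step of this size arises with neither of those features changing. Nothing available explains the size of this step.

The compounds shown do not reveal which atoms of the group of 11 heavy atoms account for the step. Going by these compounds, how an unsubstituted phenyl or a 4-chlorophenyl would read out on that oxygen also remains open.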